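Lengthening the Ester Side Chain of Compound 2

This account rests on a few compounds, and the source may have more. Where it says the series, first, only, none or still open, it means among the compounds named here.

Measured so far:
Compound 1, `O=C(CN(c1ncnc2c1ncn2C1CCCCO1)C1CC1)N[C@@H](CO)C(=O)OCc1ccccc1`, gives 29.2% in a functional assay on the whole organism (Tail, strain ICR) with Mus musculus as the target, in the tail flick test, with a stated time of 120 min, at a dose of 25 umol/kg by the oral route; on this read-out higher numbers stand for a stronger effect at the one dose given and lower numbers for a weaker effect.
Compound 2, `O=C(CN(c1nc(Cl)nc2[nH]cnc12)C1CC1)N[C@@H](CC(=O)OCc1ccccc1)C(=O)OCc1ccccc1`, gives 12.1% in this assay.
Compound 3, `O=C(OCc1ccccc1)[C@@H]1CCCN1C(=O)CN(c1nc(Cl)nc2[nH]cnc12)C1CC1`, gives 38.4% in this assay.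

Compound 2 stands lowest of the three in this assay. Compound 1 sits above it by a margin beyond the scatter, and compound 3 lies further above it, again beyond the scatter. Compound 4, `O=C(CN(c1nc(Cl)nc2[nH]cnc12)C1CC1)N[C@@H](CCC(=O)OCc1ccccc1)C(=O)OCc1ccccc1`, has not yet been measured. It differs from compound 2 in a single place: (benzyloxycarbonyl)methyl in place of benzyloxycarbonyl on a saturated chain carbon, two bonds along the chain from an amide-type nitrogen and a carbonyl carbon. Among the compounds with values here, no measured pair shows this kind of step, so its size cannot be read from the data. The expectation is a small rise from compound 2 to compound 4, a number 5.9 percentage points higher from compound 2 to compound 4 (within the scatter), which would stay within the scatter. Compound 4 is therefore estimated at 18% in this assay, in a range from 5% to 35%.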

Compound 4, a percentage reported as activity, at one dose (the size of the read-out at that dose, not a potency): 45.9%
Beside the measured number, compound 4's estimate is 27.9 percentage points below it; the whole stated range lies below it.
By their numbers in this assay, from the lowest: compound 2; then compounds 1, 3 and 4 (each within the scatter of the next, the first and the last beyond it).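

Within the data shown here, at this saturated chain carbon, (benzyloxycarbonyl)methyl in place of benzyloxycarbonyl gives, in this assay, a number 33.8 percentage points higher from compound 2 to compound 4 (beyond the scatter), the first one-place comparison. The read-out is therefore sensitive to this small lengthening, although the entering and leaving groups have the same ring and the same hydrogen-bond donor and acceptor counts. Nothing available explains why the change has this effect.

Two chain lengths define no trend. As far as these compounds go, it remains open whether a longer chain would raise the read-out further, and how a carboxylic acid in place of the benzyl ester would fare.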